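This account rests on a few compounds, and the source may have more. Where it says the series, first, only, none or still open, it means among the compounds named here.

Compound 2 `CCCCCCOc1ccc(NS(=O)(=O)c2ccc(N3CCNC3=O)cc2)cc1` is the member of this small set whose potency the assay could not pin down: in a functional assay on MCF7 cells (Homo sapiens) for antiproliferative activity, read by sulforhodamine B assay, with a stated time of 48 h (on this read-out higher numbers stand for weaker inhibition and lower numbers for stronger inhibition), compound 2 gives > 1000 nM, which is a limit of the assay and not a number. Compound 1 `O=C1NCCN1c1ccc(S(=O)(=O)Nc2ccc(I)cc2)cc1` carries iodo where compound 2 carries hexyloxy; in this assay compound 1 gives 600 nM. For the measured compounds named here, the step of an at least 1.6-fold higher number from compound 1 to compound 2 (0.22 log units; that floor lies within the scatter) is the only direct evidence on the hexyloxy group, and its floor the limit of > 1000 nM in this assay, at which 1 of the 3 values shown sits, leaves the true size of that step open. Compound 3 `CCc1cccc(NS(=O)(=O)c2ccc(N3CCNC3=O)cc2)c1`, with 3-ethylphenyl on the sulfonamide nitrogen, gives 130 nM in this assay; the step of a 4.6-fold lower number from compound 1 to compound 3 (0.66 log units; beyond the scatter) shows that an alkyl group on the aniline ring can go with a clearly lower number. Compound 4 `CCCCc1ccc(NS(=O)(=O)c2ccc(N3CCNC3=O)cc2)cc1` has not yet been tested; it differs from compound 2 by butyl in place of hexyloxy on an aromatic carbon. Because compound 2 sits at > 1000 nM, a lower number seems more likely than a higher one, but the limit keeps the expected step uncertain. Compound 4 is expected to give 600 nM, somewhere between 200 nM and 2000 nM. That expected step is an at least 1.6-fold lower number from compound 2 to compound 4 (0.22 log units; that floor lies within the scatter).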

Compound 4, half-maximal inhibitory concentration: 770 nM
Estimate against measurement, compound 4: 1.3-fold (0.11 log units) below; low and high end bracket the measured number.
By their numbers in this assay, from the lowest: compound 3; then compounds 1 and 4 (each within the scatter of the next). At a limit, above all of these: compound 2.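

The step of a 1.3-fold higher number from compound 1 to compound 4 (0.11 log units; within the scatter) lies within the scatter, so butyl and iodo on this aromatic carbon cannot be told apart in this assay. The step of an at least 1.2-fold lower number from compound 2 to compound 4 (0.11 log units; that floor lies within the scatter) gives only a floor, also within the scatter, so it does not show that exchanging hexyloxy for butyl changes the number. Going by these compounds, the true size of that change stays open because compound 2 stands at a limit of the assay: the limit of > 1000 nM in this assay, at which 1 of the 4 values shown sits.

The compounds shown leave open how the number would respond to butoxy on this carbon, which would separate the length of the chain from the oxygen that hexyloxy carries, or to a shorter chain such as methyl. On these data alone, how an amine or a carboxylic acid would behave at this place also remains unknown.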